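Chloro position on the ring-amine aryl group of compound 1

The source may report more compounds than this note shows. Statements on the series, on what has been measured and on what is new or still open speak of the compounds shown alone.

Series notes. Compound 1 `CC1(c2ccccc2)CC(=O)N(CC(=O)N2CCN(c3ccc(Cl)cc3)CC2)C1=O` bears a 4-chlorophenyl on an amine nitrogen in a ring of the shared core. In a functional assay on the whole organism (strain CD-1) with Mus musculus as the target, with a stated time of 0.5 h (on this read-out lower numbers stand for an effect already at smaller amounts and higher numbers for an effect only at larger amounts of compound), compound 1 gives 300 mg/kg, the highest of the two numbers in hand. Compound 3 `CC1(c2ccccc2)CC(=O)N(CC(=O)N2CCN(c3ccccc3)CC2)C1=O`, the unsubstituted phenyl analogue, gives 100 mg/kg in this assay. Compound 2 `CC1(c2ccccc2)CC(=O)N(CC(=O)N2CCN(c3cccc(Cl)c3)CC2)C1=O`, with a 3-chlorophenyl at the same place, is reported in this assay as "not active" (no number reported), so no number exists for it.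

For the measured compounds named here, one measured step bears on the question: a 3.0-fold lower number from compound 1 to compound 3 (0.48 log units; beyond the scatter), a modest step that goes with removing the chloro altogether. Going by the values given here, it says nothing about where a chloro sits, and the only other positional change, compound 2, ends without a number.

Compound 4 `CC1(c2ccccc2)CC(=O)N(CC(=O)N2CCN(c3ccccc3Cl)CC2)C1=O` is the remaining isomer. The change from compound 1 is 2-chlorophenyl in place of 4-chlorophenyl on an amine nitrogen in a ring. Among the compounds with values here, nothing measured tells which direction a moved chloro takes; the same atoms are kept, so no large step is assumed, but the range is set wide because compound 2 gives "not active" (no number reported). Compound 4 is therefore expected at 300 mg/kg, within 100 mg/kg to 1000 mg/kg. The estimated step is no change at the digits printed from compound 1 to compound 4 (within the scatter).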

Compound 4, minimum effective dose: "not active" (no number reported)
Nothing numeric was reported for compound 4; the estimate stays without a comparison.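

In this assay, for the compounds shown here, compound 4 is reported as "not active" (no number reported) and so no step from compound 1 to compound 4 can be read. Nothing in hand bears on this result. The compounds shown leave open how far compound 2 and compound 4 lie from compound 1 on this read-out, and whether they differ from each other.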